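The compounds below may be only part of what the source reports. "The series", "measured", "known", "first", "only" and "open" are said of these compounds alone.

For the measured compounds named here, in a functional assay on DU-145 cells (Homo sapiens) for inhibition, read by trypan blue exclusion, with a stated time of 96 h (a lower number here means a stronger inhibitor of growth, a higher number a weaker inhibitor of growth), compound 2 `O=C(/C(=C\c1c[nH]c2ccccc12)SCc1ccc(F)cc1)c1ccc(Cl)cc1` gives 1000 nM, the only true number available so far. Compound 1 `Cc1ccc(S/C(=C/c2c(O)cc(O)cc2O)C(=O)c2ccc(Cl)cc2)cc1` gives > 100000 nM, which is a limit of the assay and not a number. Compound 2 is therefore the one firm starting point for judging what comes next.

The next compound, compound 3 `Cc1ccc(S/C(=C/c2c[nH]c3ccccc23)C(=O)c2ccc(Cl)cc2)cc1`, keeps the rest of compound 2 and makes a single exchange: 4-methylphenyl in place of 4-fluorobenzyl on a sulfur. Going by the values given here, no pair of measured compounds shows this exchange on its own, so the data offer no direct guide to its size. The expectation has to start from compound 2 at 1000 nM and stay cautious.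

A moderate loss of growth inhibition is expected, though a result within the usual scatter of compound 2 would be no surprise. The expected step is a 2.5-fold higher number from compound 2 to compound 3 (0.40 log units; beyond the scatter), towards weaker inhibition, and it carries wide uncertainty. For compound 3 the estimated value in this assay is 2500 nM, with an expected range from 500 nM to 15000 nM.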

Compound 3, concentration for 50% growth inhibition: 10000 nM
Compound 3: middle estimate off by 4.0-fold (0.60 log units), on the low side; low and high end bracket the measured number.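

In this assay, for the compounds shown here, the step for 4-methylphenyl in place of 4-fluorobenzyl on the sulfur is a 10-fold higher number from compound 2 to compound 3 (1.00 log units; beyond the scatter), the first direct reading of this exchange, and it shows that the group on the sulfur matters for growth inhibition. The exchange alters two things at once: the fluorine leaves and a methyl enters, and the benzyl carbon is lost as well, so the step cannot be credited to either change alone. On these data alone, with 4-methylphenyl kept on the sulfur, 1H-indol-3-yl in place of 2,4,6-trihydroxyphenyl on the double-bonded chain carbon gives an at least 10-fold lower number from compound 1 to compound 3 (1.00 log units; beyond the scatter), which shows that the other end of the molecule matters too, although the true size of that step stays unknown.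

Compound 1 gives > 100000 nM, which is a limit of the assay and not a number.

Still open, as far as these compounds go, is which part of the exchange carries the loss, a question that a plain benzyl or a 4-fluorophenyl on the sulfur could help to settle. Also open, from the compounds shown here alone, is how a longer chain or an amine at this position would compare.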